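Shortening the Amide Chain of Compound 2

A few compounds are considered here, and "the series" means these few. Any claim that something is new, unique, unknown or untested is made for them only; others in the source may bear on it.

Compound 2 `CCCC(=O)Nc1cccc(C(=O)/C=C/c2ccc(O)c(OC)c2)c1` stands highest of the two numbers in a functional assay on HUVEC cells (Homo sapiens) for inhibition, tested at 10 ug/mL (on this read-out lower numbers stand for a weaker effect and higher numbers for a stronger effect at the one concentration tested), where compound 2 gives 87%. Compound 1 `COc1cc(/C=C/C(=O)c2cccc(NC(=O)C(C)C)c2)ccc1O` gives 56% in this assay, and the step of a number 31 percentage points higher from compound 1 to compound 2 (beyond the scatter) came with propyl in place of isopropyl on a carbonyl carbon. Compound 3 `COc1cc(/C=C/C(=O)c2cccc(NC(C)=O)c2)ccc1O` differs from compound 2 by hydrogen in place of ethyl on a saturated chain carbon bound to a carbonyl carbon. Among the measured compounds shown here, no measured step bears directly on this change, since the one step known concerns branching rather than chain length, so only a moderate fall is expected, as a number 22 percentage points lower from compound 2 to compound 3 (beyond the scatter). Compound 3 is estimated at 65% in this assay, between 40% and 90%.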

Compound 3, a percentage reported as inhibition, at one concentration (the size of the read-out at that concentration, not a potency): 32%
The estimate for compound 3 lay 33 percentage points above the measured number; measured number outside the range, below it.
By their numbers in this assay, from the lowest: compound 3; then compound 1; then compound 2.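

Chain length at this position matters as well as branching: in this assay, propyl to methyl gives a number 55 percentage points lower from compound 2 to compound 3 (beyond the scatter), and isopropyl to methyl gives a number 24 percentage points lower from compound 1 to compound 3 (beyond the scatter). Among these three amides the number therefore falls from propyl through isopropyl to methyl, so methyl gives the lowest number and neither larger group matches propyl. No evidence given here accounts for this order. The compounds shown leave open whether a longer chain, such as pentyl, would raise the number further or lower it, and whether a chain ending in an amine or a carboxylic acid would keep it.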